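Swapping the hydroxamic acid for a phenol amide

A few compounds are considered here, and "the series" means these few. Any claim that something is new, unique, unknown or untested is made for them only; others in the source may bear on it.

Within the data shown here, in an assay on isolated protein for inhibition of Apoptosis regulator Bcl-2 (Homo sapiens), read by fluorescence polarization, with stated times of 5 min and 10 min (a higher number here means a weaker inhibitor, a lower number a stronger inhibitor), compound 3 `CC(C)=CCCC1=CC[C@@H](C(=O)NO)[C@H](c2ccccc2)C1` gives 700 nM, the only real number among three results. Compound 1 `COC(=O)CCNC(=O)[C@@H]1CC=C(CCC=C(C)C)C[C@H]1c1ccccc1` reaches only the limit of > 23000 nM in this assay. Compound 2 `CC(C)=CCCC1=CC[C@H](C(=O)Nc2ccc(O)cc2)[C@@H](c2ccccc2)C1` likewise stops at the limit of > 23000 nM in this assay. Among the measured compounds shown here, the one measured step, an at least 32-fold lower number from compound 1 to compound 3 (1.51 log units; beyond the scatter), shows how much the group on the amide nitrogen matters, with the limit of > 23000 nM in this assay, at which 2 of the 3 values shown sit, marking where the weaker partner sits. Compound 4 `CC(C)=CCCC1=CC[C@@H](C(=O)Nc2ccc(O)cc2)[C@H](c2ccccc2)C1` carries 4-hydroxyphenyl in place of hydroxy on an amide-type nitrogen. Because the hydroxy is the only variant that produced a number, and the limit of > 23000 nM in this assay, at which 2 of the 3 values shown sit, holds the others, compound 4 is expected to lose potency, with an estimated step of a 21-fold higher number from compound 3 to compound 4 (1.33 log units; beyond the scatter). Compound 4 is therefore estimated at 15000 nM, between 3000 nM and 40000 nM.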

Compound 4, inhibition constant: > 23000 nM
Compound 4 ended at the assay's limit; the forecaster's own chance of this, stated with the estimate: 55%; at least 1.5-fold (0.18 log units) between middle value and limit.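

With the drawn configuration kept, 4-hydroxyphenyl in place of hydroxy on the amide nitrogen gives an at least 32-fold higher number from compound 3 to compound 4 (1.51 log units; beyond the scatter) in this assay, so this configuration alone does not rescue the phenol amide. The steps to compound 4 from compound 1 and compound 2 cannot be read, since both ends of each sit at a limit: the limit of > 23000 nM in this assay, at which 3 of the 4 values shown sit. Any effect of configuration on this amide therefore stays hidden: the fact that compounds 2 and 4 differ only in the configuration as drawn. Open, from the compounds shown here alone, is whether a methoxy or an amino group on this nitrogen would give a measurable number like hydroxy.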